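The source may hold more compounds than are shown below. What is called first, only, known or untested is meant among the compounds shown, and "the series" means these compounds.

Compound 1 `COc1cc2nccc(Oc3ccc4c(NC(=O)C5CC5)nn(C)c4c3)c2cc1OC`: > 1000 nM (a limit)
Compound 2 `COc1cc2nccc(Oc3ccc4c(NC(=O)c5cc(Cl)ccn5)nn(C)c4c3)c2cc1OC`: > 1000 nM (a limit)

In a functional assay on HUVEC cells (Homo sapiens) for inhibition, with stated times of 2 h and 72 h (on this read-out lower numbers stand for stronger inhibition and higher numbers for weaker inhibition), compound 2 stands at > 1000 nM, which is a limit of the assay and not a number. Both known results sit at one boundary: the limit of > 1000 nM in this assay, at which 2 of the 2 values shown sit. Compound 3 `COc1cccc(Nc2nn(C)c3cc(Oc4ccnc5cc(OC)c(OC)cc45)ccc23)c1` carries 3-methoxyphenyl in place of (4-chloropyridin-2-yl)carbonyl on a nitrogen on an aromatic ring. Among the compounds with values here, the only measured step is a step that the two limits leave unreadable from compound 1 to compound 2, so it offers no size to carry over. The expected change is a step that the limit leaves unreadable from compound 2 to compound 3, and the data support no firm direction. For compound 3 the estimated value is 1500 nM, with an expected range from 300 nM to 10000 nM.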

Compound 3, half-maximal inhibitory concentration: > 1000 nM
Compound 3: no number, only a limit; the forecaster's own chance of this, stated with the estimate: 65%; the middle value is on the limit's open side.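

Compound 3 gives > 1000 nM, which is a limit and not a number. No step among compound 1, compound 2 and compound 3 can be read, as all three share one boundary: the limit of > 1000 nM in this assay, at which 3 of the 3 values shown sit.

The compounds shown leave open how strong each one really is, and whether swapping these groups on the nitrogen changes anything.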